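The source may hold more compounds than are shown below. What is called first, only, known or untested is meant among the compounds shown, and "the series" means these compounds.

Among the measured compounds shown here, in a functional assay on the whole organism with Mus musculus as the target (on this read-out higher numbers stand for an effect only at larger amounts of compound and lower numbers for an effect already at smaller amounts), compound 2 (`Cn1nc(-c2ccc(Cl)cc2)n(C)c1=S`) gives 0.27 mg/kg and stands lowest of the two numbers so far, while compound 1 (`COc1ccc(-c2nn(C)c(=S)n2C)cc1`) gives 3.3 mg/kg. Compound 3 (`Cn1nc(-c2ccccc2)n(C)c1=S`) differs from compound 2 by hydrogen in place of chloro on an aromatic carbon ( hydrogen in place of chloro on an aromatic carbon ). For the measured compounds named here, the only measured step that bears on this is the large one of a 12-fold lower number from compound 1 to compound 2 (1.09 log units; beyond the scatter), where chloro replaced methoxy on an aromatic carbon. Going by the values given here, no measured compound yet carries hydrogen there, so a moderate rise in this assay is expected, smaller than that step. The expected change is a 3.7-fold higher number from compound 2 to compound 3 (0.57 log units; beyond the scatter). For compound 3 the estimated value is 1 mg/kg, within an expected range of 0.3 mg/kg to 3.5 mg/kg.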

Compound 3, dose for half-maximal effect: 0.13 mg/kg
The estimate for compound 3 lay 7.7-fold (0.89 log units) above the measured number; measured number outside the range, below it.
By their numbers in this assay, from the lowest: compound 3; then compound 2; then compound 1.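

At this aromatic carbon, compound 3 supplies the unsubstituted reference that the earlier pair lacked. In this assay, hydrogen outdoes chloro (a 2.1-fold lower number from compound 2 to compound 3 (0.32 log units; beyond the scatter)) and leads methoxy by more (a 25-fold lower number from compound 1 to compound 3 (1.40 log units; beyond the scatter)), so the earlier gain from methoxy to chloro reflects a penalty from methoxy that chloro carries less of, not a benefit from chloro itself. No evidence on the reason for this order is at hand. Going by these compounds, whether any group at this carbon can beat hydrogen remains open: fluoro, methyl, an amine or a nitrile might do so. Changes elsewhere on the shared core also remain open.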